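This account rests on a few compounds, and the source may have more. Where it says the series, first, only, none or still open, it means among the compounds named here.

Of the compounds shown here, three sharing one core have been measured for antiproliferative activity. Compound 1 `O=C(Nc1cc(-c2ccccc2)[nH]n1)c1ccc(Br)nc1` gives 6730 nM in a functional assay on WM 266-4 cells (Homo sapiens) for antiproliferative activity, read by MTT assay, with a stated time of 48 h; a higher number here means a weaker inhibitor, a lower number a stronger inhibitor. Compound 2 `O=C(Nc1cc(-c2ccccc2)[nH]n1)c1ccc(Cl)nc1` differs from compound 1 in one place: chloro in place of bromo on an aromatic carbon In this assay compound 2 gives 6430 nM, and the step is a 1.0-fold lower number from compound 1 to compound 2 (0.02 log units; within the scatter). Compound 3 `O=C(Nc1cc(-c2ccc(Br)cc2)[nH]n1)c1ccc(Br)nc1` differs from compound 1 in another place: bromo in place of hydrogen on an aromatic carbon In this assay compound 3 gives 8560 nM, the step being a 1.3-fold higher number from compound 1 to compound 3 (0.10 log units; within the scatter).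

Compound 4 `O=C(Nc1cc(-c2ccc(Br)cc2)[nH]n1)c1ccc(Cl)nc1` has not yet been measured. Going by the values given here, it differs from compound 3 as follows: chloro in place of bromo on an aromatic carbon This is the same change, at the same place, as the one made from compound 1 to compound 2; the two cores differ only in the way just described for compound 3 against compound 1. Because the earlier step was a 1.0-fold lower number from compound 1 to compound 2 (0.02 log units; within the scatter), the expected step here is a 1.0-fold lower number from compound 3 to compound 4 (0.01 log units; within the scatter). Compound 4 is therefore estimated to give about 8300 nM in this assay. For compound 4 the expected range runs from 4500 nM to 15000 nM.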

Compound 4, half-maximal inhibitory concentration: 7470 nM
Estimate against measurement, compound 4: 1.1-fold (0.05 log units) above; the measured number falls inside the stated range.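

In this assay, the change from 6-bromopyridin-3-yl to 6-chloropyridin-3-yl gives a 1.1-fold lower number from compound 3 to compound 4 (0.06 log units; within the scatter), and the step on this core matches the step on the core of compound 1: the same change on two cores in this assay, a 1.0-fold lower number (0.02 log units; within the scatter) from compound 1 to compound 2 and a 1.1-fold lower number (0.06 log units; within the scatter) from compound 3 to compound 4, 1.1-fold (0.04 log units) apart, within the scatter of two such steps. The other change, bromo in place of hydrogen on an aromatic carbon, gives a 1.2-fold higher number from compound 2 to compound 4 (0.07 log units; within the scatter), and it also matches its earlier step: the same change on two cores in this assay, a 1.3-fold higher number (0.10 log units; within the scatter) from compound 1 to compound 3 and a 1.2-fold higher number (0.07 log units; within the scatter) from compound 2 to compound 4, 1.1-fold (0.04 log units) apart, within the scatter of two such steps. Going by these compounds alone, all four steps lie within the scatter, so the series shows only that neither change moves the number measurably on either core, and it does not show that a change with a clear effect would carry from one core to another in the same way.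

The four compounds hold only hydrogen, bromo or chloro at these two places. Going by these compounds, whether an amine or a carboxylic acid at either place would produce a step beyond the scatter, and whether that step would be the same on both cores, remains open.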